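A few compounds are considered here, and "the series" means these few. Any claim that something is new, unique, unknown or untested is made for them only; others in the source may bear on it.

In a functional assay on DU-145 cells (Homo sapiens) for inhibition, read by trypan blue exclusion, with a stated time of 96 h (a lower number here means a stronger inhibitor of growth, a higher number a weaker inhibitor of growth), compound 2 `Cc1ccc(CS(=O)(=O)/C(=C/c2cccc(Cl)c2Cl)C(=O)c2ccc(Cl)cc2)cc1` gives 1000 nM. Compound 3 `O=C(O)c1ccc(C(=O)/C(=C\c2ccc(F)c([N+](=O)[O-])c2)SCc2ccc(Cl)cc2Cl)cc1` gives 1000 nM, level with compound 2 at the digits shown, and these two share the lowest number of the three measured. Compound 1 `Cc1ccc(CS(=O)(=O)/C(=C/c2c[nH]c3ccc(Br)cc23)C(=O)c2ccc(Cl)cc2)cc1` gives 10000 nM, the highest of the three. Going by the values given here, the only measured step that touches the same place as the new compound is a 10-fold lower number from compound 1 to compound 2 (1.00 log units; beyond the scatter). Compound 4 `Cc1ccc(CS(=O)(=O)/C(=C/c2sccc2C)C(=O)c2ccc(Cl)cc2)cc1` differs from compound 2 in one place: 3-methylthiophen-2-yl in place of 2,3-dichlorophenyl on a double-bonded chain carbon bound to a double-bonded chain carbon. That earlier step shows a swap at this place can shift the number by a modest amount, but nothing measured says which way a five-membered ring with one hetero atom will go. Compound 4 is therefore expected to give about 2000 nM, between 500 nM and 10000 nM. The expected step is a 2.0-fold higher number from compound 2 to compound 4 (0.30 log units; within the scatter).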

Compound 4, concentration for 50% growth inhibition: 25000 nM
For compound 4 the middle estimate is 13-fold (1.10 log units) below the measured one, and the stated range ends below it.
By their numbers in this assay, from the lowest: compounds 2 and 3 (each within the scatter of the next); then compound 1; then compound 4.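

Going by these compounds alone, the ring at this place matters more than the earlier compounds showed: 3-methylthiophen-2-yl in place of 2,3-dichlorophenyl brings a 25-fold higher number from compound 2 to compound 4 (1.40 log units; beyond the scatter) and is a large step, where the only earlier step was modest. The same ring also trails 5-bromo-1H-indol-3-yl, with a 2.5-fold higher number from compound 1 to compound 4 (0.40 log units; beyond the scatter) as the step, so among these three groups the five-membered ring gives the highest number. Nothing measured here explains this order. From the compounds shown here alone, it remains open whether the loss follows the sulfur-containing ring or its methyl group. A plain thiophene or a pyridine ring at this place could separate the two.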